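Benzamido Cap in Place of Benzyl on a Chromobox 7 Peptide

The source may report more compounds than this note shows. Statements on the series, on what has been measured and on what is new or still open speak of the compounds shown alone.

Compound 1, `CC(C)C[C@H](NC(=O)[C@H](C)NC(=O)c1ccccc1)C(=O)N[C@@H](CCCC[N+](C)(C)C)C(=O)N[C@@H](CO)C(N)=O`, 57000 nM
Compound 2, `CC(C)C[C@H](NC(=O)[C@H](C)NC(=O)CCc1ccccc1)C(=O)N[C@@H](CCCC[N+](C)(C)C)C(=O)N[C@@H](CO)C(N)=O`, 26000 nM

The two compounds were measured in an assay on isolated protein for displacement of a labelled ligand from Chromobox protein homolog 7 (Homo sapiens), read by fluorescence polarization, with a stated time of 15 min; a lower number here means a stronger inhibitor, a higher number a weaker inhibitor. Compound 2 stands at the lowest of the two numbers; its nearest neighbour is compound 1, and the step of a 2.2-fold lower number from compound 1 to compound 2 (0.34 log units; beyond the scatter) is beyond the scatter but modest.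

Compound 3, `CC(C)C[C@H](NC(=O)[C@H](C)NC(=O)CNC(=O)c1ccccc1)C(=O)N[C@@H](CCCC[N+](C)(C)C)C(=O)N[C@@H](CO)C(N)=O`, has not yet been measured. It differs from compound 2 by benzamido in place of benzyl on a saturated chain carbon bound to a carbonyl carbon. For the measured compounds named here, only one measured step bears on this part of the molecule, the step from compound 1 to compound 2, in which phenethyl replaced phenyl on the carbonyl carbon and gave a modest gain. Compound 3 keeps the phenyl ring at a similar distance from the carbonyl through a benzamidomethyl chain rather than phenethyl, so no step beyond the scatter is expected in this assay, and if anything a slight drift back towards the number of compound 1, 57000 nM, is allowed for.

Compound 3 is therefore estimated at 32000 nM, within a range of 11000 nM to 95000 nM, which corresponds to the expected step of a 1.2-fold higher number from compound 2 to compound 3 (0.09 log units; within the scatter).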

Compound 3, half-maximal inhibitory concentration: 58000 nM
Compound 3: the middle estimate sits 1.8-fold (0.26 log units) below what was measured; measured number inside the range.
By their numbers in this assay, from the lowest: compound 2; then compounds 1 and 3 (each within the scatter of the next).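

In this assay, benzamido in place of benzyl on a saturated chain carbon bound to a carbonyl carbon gives a 2.2-fold higher number from compound 2 to compound 3 (0.35 log units; beyond the scatter) and so shows that this position does not accept every chain that holds the phenyl ring away from the carbonyl carbon. Set against the phenyl group alone, the benzamidomethyl chain gives a 1.0-fold higher number from compound 1 to compound 3 (0.01 log units; within the scatter) and thus leaves no measurable gain, so the modest gain seen with phenethyl does not carry over to the benzamidomethyl chain even though that chain also separates the ring from the carbonyl carbon. No measurement at hand accounts for the difference between these two chains.

The compounds shown leave open whether the loss follows the amide within the chain or the chain's particular length, and a simple carbon chain one unit longer than phenethyl, or a phenoxymethyl chain with an ether oxygen in the same stretch, would bear on that question. They also leave open whether a substituent on the phenyl ring, such as a fluorine or a methoxy group, would shift the number for either chain.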